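This account rests on a few compounds, and the source may have more. Where it says the series, first, only, none or still open, it means among the compounds named here.

Measured compounds:
Compound 1 `C=CNCc1cc(-c2c(C(=O)NCC)noc2-c2cc(C(C)C)c(O)cc2O)on1` gives 43 nM in a functional assay on A2780 cells (Homo sapiens) for inhibition; a higher number here means a weaker inhibitor, a lower number a stronger inhibitor.
For compound 2 `CCCN(CCC)Cc1cc(-c2c(C(=O)NCC)noc2-c2cc(C(C)C)c(O)cc2O)on1` the entry in this assay reads "not determined" (no result reported), so no result was reported for it.

Among the measured compounds shown here, compound 1 is therefore the only compound of the set with a number, and it stands alone. Compound 3 `CCNC(=O)c1noc(-c2cc(C(C)C)c(O)cc2O)c1-c1cc[nH]n1` has not yet been measured. It differs from compound 1 in one place: 1H-pyrazol-3-yl in place of 3-((vinylamino)methyl)-1,2-oxazol-5-yl on an aromatic carbon. For the measured compounds named here, no step between measured compounds exists to calibrate this change, so the expected size rests on the structures alone. The loss of the larger group is expected to weaken inhibition somewhat, a step of a 3.7-fold higher number from compound 1 to compound 3 (0.57 log units; beyond the scatter) beyond the usual scatter. Compound 3 is estimated at 160 nM in this assay, within 40 nM to 650 nM.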

Compound 3, half-maximal inhibitory concentration: 33 nM
Compound 3: the middle estimate sits 4.8-fold (0.69 log units) above what was measured, outside the stated range (below it).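

Exchanging 3-((vinylamino)methyl)-1,2-oxazol-5-yl for 1H-pyrazol-3-yl on this aromatic carbon gives a 1.3-fold lower number from compound 1 to compound 3 (0.11 log units; within the scatter) in this assay. At this position, then, the larger group can give way to the smaller ring with no change beyond the scatter, and the side chain of compound 1 is not required for a value of this size. Nothing available explains why the two compounds read alike.

The compounds shown leave open whether a group without a ring here, such as a primary amine or a carboxylic acid, would keep this value. They also leave open how other five-membered rings, such as an imidazole, would compare.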